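This account rests on a few compounds, and the source may have more. Where it says the series, first, only, none or still open, it means among the compounds named here.

Measured so far:
compound 1 `Oc1cc(C(F)(F)F)ccc1-c1nc(-c2ccccc2O)n(-c2ccc(Br)cc2)n1` — 89.8%
compound 2 `Oc1cc(C(F)(F)F)ccc1-c1nc(-c2ccccc2O)n(-c2ccc(C(F)(F)F)cc2)n1` — 90.5%
compound 3 `COc1ccc(-n2nc(-c3ccc(C(F)(F)F)cc3O)nc2-c2ccccc2O)cc1` — 86.6%

In a functional assay on PC-12 cells (Rattus norvegicus) for cytotoxicity, read by MTT assay, with stated times of 2 h and 24 h, tested at 5 uM (on this read-out higher numbers stand for a stronger effect at the one concentration tested and lower numbers for a weaker effect), compound 3 holds the lowest of the three numbers, yet both steps reaching it, a number 3.2 percentage points lower from compound 1 to compound 3 (within the scatter) and a number 3.9 percentage points lower from compound 2 to compound 3 (within the scatter), lie within the scatter, so it stands level with the others. Compound 4 `Oc1cc(C(F)(F)F)ccc1-c1nc(-c2ccccc2O)n(-c2cccc(F)c2)n1` differs from compound 3 by 3-fluorophenyl in place of 4-methoxyphenyl on an aromatic nitrogen. All three measured steps swap the group on this aromatic nitrogen: a number 0.7 percentage points higher from compound 1 to compound 2 (within the scatter), a number 3.2 percentage points lower from compound 1 to compound 3 (within the scatter) and a number 3.9 percentage points lower from compound 2 to compound 3 (within the scatter), none beyond the scatter. The expected step of a number 1.4 percentage points higher from compound 3 to compound 4 (within the scatter) is therefore also none beyond the scatter. Compound 4 is expected to give 88% in this assay, estimated between 78% and 96%.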

Compound 4, a percentage reported as activity, at one concentration (the size of the read-out at that concentration, not a potency): 87.7%
For compound 4 the middle estimate is 0.3 percentage points above the measured one, and the stated range covers the measured number.
By their numbers in this assay, from the lowest: compounds 3, 4, 1 and 2 (each within the scatter of the next).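

The 3-fluorophenyl group on this aromatic nitrogen reads level with 4-methoxyphenyl (a number 1.1 percentage points higher from compound 3 to compound 4 (within the scatter)), with 4-(trifluoromethyl)phenyl (a number 2.8 percentage points lower from compound 2 to compound 4 (within the scatter)) and with 4-bromophenyl (a number 2.1 percentage points lower from compound 1 to compound 4 (within the scatter)) in this assay for these four compounds. A fluoro group at the 3-position of this phenyl therefore gives no step beyond the scatter, so the flat picture at this nitrogen now extends past the three 4-substituted phenyl groups. Nothing available explains this flat read-out.

Open, as far as these compounds go, is whether an amine or a carboxylic acid on this phenyl, or a butyl chain in its place, would give a step beyond the scatter. Also open, from the compounds shown here alone, is how the read-out responds to a change at the 2-hydroxyphenyl group.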